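Furan in place of a substituted benzene ring

The compounds below may be only part of what the source reports. "The series", "measured", "known", "first", "only" and "open" are said of these compounds alone.

Measured compounds:
compound 1, `NCc1cc(CO)ccc1CN(Cc1nc2ccccc2[nH]1)C1CCCc2cccnc21`: 11 nM
compound 2, `COC(=O)c1ccc(CN(Cc2nc3ccccc3[nH]2)C2CCCc3cccnc32)c(CN)c1`: 39 nM

In a functional assay on CEM-CCRF cells for antagonist activity at C-X-C chemokine receptor type 4 (Homo sapiens), read by calcium flux (a lower number here means a stronger inhibitor, a higher number a weaker inhibitor), compound 1 gives the lower of the two numbers shown, and compound 2 sits a 3.5-fold higher number from compound 1 to compound 2 (0.55 log units; beyond the scatter) away, a change made by putting methoxycarbonyl in place of hydroxymethyl on an aromatic carbon.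

Compound 3, `NCc1occc1CN(Cc1nc2ccccc2[nH]1)C1CCCc2cccnc21`, has not been measured yet. It differs from compound 1 by a group of 7 heavy atoms (5 carbon, 1 nitrogen, 1 oxygen; one five-membered aromatic ring with 1 hetero atom) in place of a group of 10 heavy atoms (8 carbon, 1 nitrogen, 1 oxygen; one six-membered aromatic ring of carbon only), on a saturated chain carbon bound to an amine nitrogen. For the measured compounds named here, no measured step covers this kind of change; the only step at hand, a 3.5-fold higher number from compound 1 to compound 2 (0.55 log units; beyond the scatter), alters one substituent while the six-membered ring stays, and it produced a modest loss. Since that smaller change already cost something, a ring replacement that also removes a hydroxymethyl is expected to move the number in the same direction, by a modest margin, a 2.7-fold higher number from compound 1 to compound 3 (0.44 log units; beyond the scatter). Compound 3 is therefore estimated at 30 nM, within 10 nM to 90 nM.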

Compound 3, half-maximal inhibitory concentration: 21 nM
Beside the measured number, compound 3's estimate is 1.4-fold (0.15 log units) above it, within the range that was stated.
By their numbers in this assay, from the lowest: compounds 1, 3 and 2 (each within the scatter of the next, the first and the last beyond it).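

In this assay the furan in place of the substituted benzene ring gives a 1.9-fold higher number from compound 1 to compound 3 (0.28 log units; within the scatter) and so leaves the two compounds indistinguishable in this measurement. The earlier pair changed only one substituent while the six-membered ring stayed; this result shows that the whole group on a saturated chain carbon bound to an amine nitrogen can be exchanged for one with fewer heavy atoms, without the hydroxymethyl, and with one hydrogen-bond donor fewer, while the number stays within the scatter. No measurement at hand accounts for this outcome.

Open, on these data alone, is whether a thiophene or a pyridine ring in the same place would behave like the furan. Also open, as far as these compounds go, is what a hydroxymethyl or a methoxycarbonyl group on the furan itself would do.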